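Compound 2 and a new hydroxy: growth inhibition notes

This account rests on a few compounds, and the source may have more. Where it says the series, first, only, none or still open, it means among the compounds named here.

Of the compounds shown here, three sharing one core have been read in a functional assay on ZR-75-1 cells (Homo sapiens) for inhibition, read by sulforhodamine B assay; a higher number here means a weaker inhibitor of growth, a lower number a stronger inhibitor of growth. Compound 1 `FC(F)(F)c1ccc(-c2ccc(-c3ccc(-c4nc5ccccc5[nH]4)cc3)cc2)cc1` gives 48300 nM, compound 2 `FC(F)(F)Oc1ccc(-c2ccc(-c3ccc(-c4nc5ccccc5[nH]4)cc3)cc2)cc1` gives 100000 nM and compound 3 `CN(C)c1ccc(-c2ccc(-c3ccc(-c4nc5ccccc5[nH]4)cc3)cc2)cc1` gives 100000 nM. Compound 2 therefore stands level with compound 3, together at the top of the three numbers.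

Compound 4 `Oc1cccc2[nH]c(-c3ccc(-c4ccc(-c5ccc(OC(F)(F)F)cc5)cc4)cc3)nc12` keeps the trifluoromethoxy group of compound 2 and carries hydroxy in place of hydrogen on an aromatic carbon, turning 1H-benzimidazol-2-yl into 4-hydroxy-1H-benzimidazol-2-yl (hydroxy in place of hydrogen on an aromatic carbon).

The measured steps all concern a different place on the core: a 2.1-fold higher number from compound 1 to compound 2 (0.32 log units; beyond the scatter), a 2.1-fold higher number from compound 1 to compound 3 (0.32 log units; beyond the scatter) and no change at the digits printed from compound 2 to compound 3 (within the scatter). None of them tests a hydroxy, so the data give no direct measure of this change and only a rough sense of scale. Across these steps the numbers have moved modestly or not at all. With compound 2 at 100000 nM, no higher number has yet been seen in the series, so a move downward is the likelier direction, though no change remains possible. The expected change is a 2.2-fold lower number from compound 2 to compound 4 (0.35 log units; beyond the scatter), a modest step toward a lower number. For compound 4 the estimated value is 45000 nM, with an expected range of 8000 nM to 100000 nM.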

Compound 4, concentration for 50% growth inhibition: 3800 nM
Beside the measured number, compound 4's estimate is 12-fold (1.07 log units) above it; the measured number lies below the stated range.
By their numbers in this assay, from the lowest: compound 4; then compound 1; then compounds 2 and 3 (each within the scatter of the next).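

Turning 1H-benzimidazol-2-yl into 4-hydroxy-1H-benzimidazol-2-yl gives a 26-fold lower number from compound 2 to compound 4 (1.42 log units; beyond the scatter) in this assay, a large step toward stronger inhibition of growth. For the compounds shown here, the earlier exchanges among trifluoromethyl, trifluoromethoxy and dimethylamino, all at a different place on the shared core, gave only a 2.1-fold higher number from compound 1 to compound 2 (0.32 log units; beyond the scatter), a 2.1-fold higher number from compound 1 to compound 3 (0.32 log units; beyond the scatter) and no change at the digits printed from compound 2 to compound 3 (within the scatter), so this aromatic carbon, ortho to a fused ring and meta to a fused ring, is the first place where a single change moves the number by a large step. No measurement shown here accounts for the size of this step.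

The compounds shown leave open whether a methoxy or an amino group on this same carbon would give a step of similar size, and so whether the effect is particular to hydroxy. Going by these compounds alone, they also leave open whether the step carries over to the trifluoromethyl and dimethylamino members, as it rests on the single pair of compound 2 and compound 4.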